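Replacing a sulfonate ester with bromine on the phenyl ring

The source may hold more compounds than are shown below. What is called first, only, known or untested is meant among the compounds shown, and "the series" means these compounds.

Of the compounds shown here, three that share one core have been measured in an assay for inhibition of Dihydrofolate reductase (Gallus gallus); on this read-out higher numbers stand for weaker inhibition and lower numbers for stronger inhibition. Compound 1 `Nc1ncc(Cc2ccccc2O)c(N)n1` gives 89100 nM. Compound 2 `CCOc1ccccc1Cc1cnc(N)nc1N` gives 24500 nM, and compound 3 `CS(=O)(=O)Oc1ccccc1Cc1cnc(N)nc1N` gives 22900 nM. Compound 3 has the lowest number of the three, though its gap to compound 2 is within the scatter; the step of a 3.9-fold lower number from compound 1 to compound 3 (0.59 log units; beyond the scatter) is the only one from it that is beyond the scatter. The measured steps show that adding ethyl or methylsulfonyl to the oxygen lowers the number modestly, as in a 3.6-fold lower number from compound 1 to compound 2 (0.56 log units; beyond the scatter), while swapping one for the other, a 1.1-fold lower number from compound 2 to compound 3 (0.03 log units; within the scatter), changes little.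

Compound 4 `Nc1ncc(Cc2ccccc2Br)c(N)n1` is not yet measured. It differs from compound 3 by bromo in place of (methylsulfonyl)oxy on an aromatic carbon. Among the compounds with values here, no measured step removes the oxygen or introduces a halogen, so the earlier steps give only indirect guidance. The number is expected to sit between compound 1 and compound 3, with the step of a 1.7-fold higher number from compound 3 to compound 4 (0.24 log units; within the scatter) estimated. Compound 4 is therefore expected to give about 40000 nM, in a range from 10000 nM to 160000 nM.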

Compound 4, inhibition constant: 12300 nM
Beside the measured number, compound 4's estimate is 3.3-fold (0.51 log units) above it; measured number inside the range.
By their numbers in this assay, from the lowest: compounds 4, 3 and 2 (each within the scatter of the next); then compound 1.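

In this assay, an oxygen on this aromatic carbon is not required for a number in the range of compound 2 and compound 3. Bromo, with 1 heavy atom and 0 hydrogen-bond acceptors, takes the place of (methylsulfonyl)oxy, with 5 heavy atoms and 3 hydrogen-bond acceptors, in a 1.9-fold lower number from compound 3 to compound 4 (0.27 log units; within the scatter), and it replaces ethoxy in a 2.0-fold lower number from compound 2 to compound 4 (0.30 log units; within the scatter), so neither step separates the groups, while hydroxy stands apart in a 7.2-fold lower number from compound 1 to compound 4 (0.86 log units; beyond the scatter). The data shown offer no measured explanation for this pattern.

On these data alone, it remains open whether chlorine, fluorine, an amine or a carboxylic acid on this carbon would give a number like that of compound 4 or like that of compound 1. The same question applies to a longer chain on the oxygen.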